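Bromo in place of methyl on the shared core

The compounds below may be only part of what the source reports. "The series", "measured", "known", "first", "only" and "open" are said of these compounds alone.

Of the compounds shown here, three built on one shared core have been measured in a functional assay on HepG2 cells (Homo sapiens) for inhibition, read by MTT assay, with a stated time of 24 h; a higher number here means a weaker inhibitor, a lower number a stronger inhibitor. Compound 1 `COc1ccccc1-n1cc(CN2C(=O)C[C@@H]3CC[C@@]2(C)C3(C)C)nn1` gives 110 nM in this assay, compound 2 `Cc1ccc(-n2cc(CN3C(=O)C[C@@H]4CC[C@@]3(C)C4(C)C)nn2)cc1` gives 480 nM, and compound 3 `COc1cccc(-n2cc(CN3C(=O)C[C@@H]4CC[C@@]3(C)C4(C)C)nn2)c1` gives 70 nM. Compound 2 stands highest of the three numbers: there is a 4.4-fold higher number from compound 1 to compound 2 (0.64 log units; beyond the scatter) and a 6.9-fold lower number from compound 2 to compound 3 (0.84 log units; beyond the scatter), both beyond the scatter, whereas a 1.6-fold lower number from compound 1 to compound 3 (0.20 log units; within the scatter) sits within it.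

Compound 4 `CC1(C)[C@H]2CC[C@]1(C)N(Cc1cn(-c3ccc(Br)cc3)nn1)C(=O)C2` is not yet measured. It differs from compound 2 by bromo in place of methyl on an aromatic carbon, the same difference reading, one bond further out, as 4-methylphenyl to 4-bromophenyl. Among the measured compounds shown here, no measured step exchanges methyl for bromo, so the measured steps bear on this one only at a distance: they show that compound 2, which carries the 4-methylphenyl, has the highest number of the three, and that the two other aryl groups give lower numbers, as a 6.9-fold lower number from compound 2 to compound 3 (0.84 log units; beyond the scatter) shows. Compound 4 keeps the substituent at the same place, so a large step is not expected in either direction. Compound 4 is therefore expected to give 320 nM in this assay, with an expected range from 110 nM to 950 nM. The expected step is a 1.5-fold lower number from compound 2 to compound 4 (0.18 log units; within the scatter), which would be within the scatter.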

Compound 4, half-maximal inhibitory concentration: 110 nM
For compound 4 the middle estimate is 2.9-fold (0.46 log units) above the measured one, within the range that was stated.
By their numbers in this assay, from the lowest: compounds 3, 1 and 4 (each within the scatter of the next); then compound 2.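

In this assay, among the compounds shown here, the exchange of methyl for bromo on the aromatic carbon para to a large group is not a neutral one at this position (a 4.4-fold lower number from compound 2 to compound 4 (0.64 log units; beyond the scatter)), which the earlier compounds could only hint at, since none of them carried a second group at this place. The high number of compound 2 therefore does not belong to every 4-substituted phenyl. The 4-bromophenyl of compound 4 falls in with the two methoxyphenyl compounds (no change at the digits printed from compound 1 to compound 4 (within the scatter); a 1.6-fold higher number from compound 3 to compound 4 (0.20 log units; within the scatter)), leaving compound 2 alone apart from the other three. No measurement shown here accounts for the gap between methyl and bromo at this place.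

Only methyl and bromo stand at this place among the compounds shown, so what chloro, methoxy or an amine would give there remains open. All four compounds also share the same core and differ only on the aryl group, so whether the step from methyl to bromo would hold on a changed core is left open as well.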